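A few compounds are considered here, and "the series" means these few. Any claim that something is new, unique, unknown or untested is made for them only; others in the source may bear on it.

Working notes on the series, measured in a functional assay on KYSE-450 cells (Homo sapiens) for inhibition, read by MTT assay, with a stated time of 48 h; a higher number here means a weaker inhibitor, a lower number a stronger inhibitor.

Compound 1 `COc1ccc(CNc2cc(OC)c(OC)c(OC)c2)cc1[N+](=O)[O-]` gives 16800 nM; compound 3 `COc1ccc(CNc2cc(OC)c(OC)c(OC)c2)cc1F` gives 46200 nM. Between them stands one single-point change, a 2.8-fold higher number from compound 1 to compound 3 (0.44 log units; beyond the scatter). Compound 2 `C#CC(=O)N(Cc1ccc(OC)c(O)c1)c1cc(OC)c(OC)c(OC)c1` gives 570 nM, the lowest of the three numbers; both compound 1 and compound 3 sit beyond the scatter above it, so compound 2 is the strongest inhibitor among the measured compounds.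

Compound 4 `COc1ccc(CN(C(=O)C(C)C)c2cc(OC)c(OC)c(OC)c2)cc1O` has not yet been measured. It differs from compound 2 in one place: isopropyl in place of ethynyl on a carbonyl carbon. For the measured compounds named here, no measured step bears on this change; the only recorded step, from compound 1 to compound 3, concerns a substituent on an aromatic carbon and says nothing about the carbonyl substituent. The measured compounds give no basis for the direction of this change, so the expectation for this step is set wide and leans toward a higher number. The change is estimated to amount to an 8.8-fold higher number from compound 2 to compound 4 (0.94 log units; beyond the scatter). Compound 4 is expected to give about 5000 nM, within the range 800 nM to 30000 nM.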

Compound 4, half-maximal inhibitory concentration: 390 nM
Compound 4: the middle estimate sits 13-fold (1.11 log units) above what was measured; the whole stated range lies above it.
By their numbers in this assay, from the lowest: compounds 4 and 2 (each within the scatter of the next); then compound 1; then compound 3.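

In this assay, isopropyl in place of ethynyl on a carbonyl carbon gives a 1.5-fold lower number from compound 2 to compound 4 (0.16 log units; within the scatter), so this pair reads as level. The ethynyl group and its triple bond are therefore not required for a value in this range at this position, at least on the core of compound 2, and a saturated branched group of one more carbon serves equally well here. Nothing at hand accounts for why the two groups read alike.

From the compounds shown here alone, whether a longer chain, a cyclopropyl group or an amine on the same carbonyl carbon would hold this level remains open. No single step shown isolates the carbonyl group itself, as compound 1 and compound 3 each differ from compound 2 in more than one place.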